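The source may report more compounds than this note shows. Statements on the series, on what has been measured and on what is new or still open speak of the compounds shown alone.

Measured so far:
- compound 1, `Cc1cccc(NC(=O)c2nn(C)c(-c3ccc(F)cc3)c2C)n1`, 1.1 nM in a functional assay on HEK293 cells for negative allosteric modulation of metabotropic glutamate receptor 5 (Homo sapiens), read by FLIPR and calcium flux; a higher number here means a weaker inhibitor, a lower number a stronger inhibitor
- compound 2, `Cc1cccc(NC(=O)c2nn(C)c(-c3ccc(C(F)(F)F)cc3)c2C)n1`, 38 nM in this assay

Going by the values given here, compound 2 holds the highest of the two numbers so far; its nearest neighbour is compound 1, and the only measured step, a 35-fold higher number from compound 1 to compound 2 (1.54 log units; beyond the scatter), lies beyond the scatter and is large. Among the compounds with values here, that step is the sole guide here: it shows that the group at this position on the ring moves the read-out strongly in this assay.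

Compound 3, `Cc1cccc(NC(=O)c2nn(C)c(-c3ccc(N(C)C)cc3)c2C)n1`, is not yet measured. It differs from compound 2 by dimethylamino in place of trifluoromethyl on an aromatic carbon. Within the data shown here, no measured pair shows this exchange, so its direction rests on the single observation that the position is sensitive, without telling which way a dimethylamino group will move the number. Given the wide span between compound 1 and compound 2, compound 3 is expected to fall somewhere within that span, estimated at 15 nM with a range of 2 nM to 120 nM. This estimate means a step of a 2.5-fold lower number from compound 2 to compound 3 (0.40 log units; beyond the scatter), expected as a moderate lowering with considerable uncertainty.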

Compound 3, half-maximal inhibitory concentration: 645 nM
Compound 3: the middle estimate sits 43-fold (1.63 log units) below what was measured; the whole stated range lies below it.
By their numbers in this assay, from the lowest: compound 1; then compound 2; then compound 3.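

In this assay, dimethylamino in place of trifluoromethyl gives a 17-fold higher number from compound 2 to compound 3 (1.23 log units; beyond the scatter) and dimethylamino in place of fluoro gives a 590-fold higher number from compound 1 to compound 3 (2.77 log units; beyond the scatter) on the same aromatic carbon. The position therefore tolerates less than compound 1 and compound 2 alone suggested: the range of numbers is far wider, and the new group falls outside the earlier pair rather than between them. Among these three compounds, fluoro gives the lowest number and both replacements raise it, but nothing here bears on the cause of this order. From the compounds shown here alone, the reading for hydrogen, chloro, methoxy or a primary amine on this carbon remains open. Also open, going by these compounds, is whether the same order would hold with these groups at another place on the ring.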